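The source may hold more compounds than are shown below. What is called first, only, known or untested is meant among the compounds shown, and "the series" means these compounds.

Working notes on the series, read in a functional assay on FM3A cells (Mus musculus) for antiproliferative activity; a lower number here means a stronger inhibitor, a higher number a weaker inhibitor. Three compounds share one core and differ in the aryl group. Compound 1 `COc1cc(C(=O)c2sc(-c3ccc([N+](=O)[O-])cc3)cc2N)cc(OC)c1OC` gives 64 nM, compound 2 `COc1cc(C(=O)c2sc(-c3cccc([N+](=O)[O-])c3)cc2N)cc(OC)c1OC` gives 17 nM, and compound 3 `COc1cc(C(=O)c2sc(-c3ccc(F)cc3)cc2N)cc(OC)c1OC` gives 16 nM. Compound 3 holds the lowest of the three numbers, but it does not stand apart from compound 2: a 1.1-fold lower number from compound 2 to compound 3 (0.03 log units; within the scatter). Its gap to the remaining compound is clearer: a 4.0-fold lower number from compound 1 to compound 3 (0.60 log units; beyond the scatter).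

The next compound is compound 4 `COc1cccc(-c2cc(N)c(C(=O)c3cc(OC)c(OC)c(OC)c3)s2)c1`, with 3-methoxyphenyl in place of 4-fluorophenyl on the aromatic carbon next to the ring sulfur: 3-methoxyphenyl in place of 4-fluorophenyl on an aromatic carbon.

Among the compounds with values here, no measured compound carries a methoxy group, so the evidence is indirect. Within the data shown here, two steps bear on the change. a 1.1-fold lower number from compound 2 to compound 3 (0.03 log units; within the scatter) shows a 3-substituted phenyl group and the 4-fluorophenyl group at the same level. a 3.8-fold lower number from compound 1 to compound 2 (0.58 log units; beyond the scatter) is a modest shift, with 3-nitrophenyl in place of 4-nitrophenyl. Among the measured compounds shown here, compound 1 is the only compound of the three set apart. Compound 4 keeps a substituent at the position held in compound 2, so no step beyond the scatter is expected in this assay. The expected change is a 1.4-fold higher number from compound 3 to compound 4 (0.14 log units; within the scatter). For compound 4 the estimated value is 22 nM, with an expected range from 7 nM to 70 nM.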

Compound 4, half-maximal inhibitory concentration: 36 nM
Estimate against measurement, compound 4: 1.6-fold (0.21 log units) below, within the range that was stated.
By their numbers in this assay, from the lowest: compounds 3 and 2 (each within the scatter of the next); then compounds 4 and 1 (each within the scatter of the next).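

In this assay the 3-methoxyphenyl group on the aromatic carbon next to the ring sulfur does not stay level with the two best aryl groups, with modest steps against 4-fluorophenyl (a 2.3-fold higher number from compound 3 to compound 4 (0.35 log units; beyond the scatter)) and against 3-nitrophenyl (a 2.1-fold higher number from compound 2 to compound 4 (0.33 log units; beyond the scatter)). The second step is the new information: 3-nitrophenyl and 3-methoxyphenyl carry their groups at the same place on the phenyl ring, yet their numbers separate, so at this position the level depends on the group itself and not only on where it sits on the phenyl ring, while compound 1 no longer stands alone, since the step to compound 4 stays within the scatter (a 1.8-fold lower number from compound 1 to compound 4 (0.25 log units; within the scatter)). Nothing on hand accounts for the separation between the methoxy and nitro groups.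

Still open, on these data alone, is whether an amine or a carboxylic acid on the phenyl ring would stay level with compound 2 and compound 3 or fall with compound 4. As far as these compounds go, it is equally open whether a longer alkoxy chain in place of methoxy would move the number any further from that level.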